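This account rests on a few compounds, and the source may have more. Where it says the series, first, only, none or still open, it means among the compounds named here.

Compound 3 `CC(C)(C)c1cc(C(=O)Nc2ccncc2)n(Cc2ccccc2)n1` stands second highest among the three measured values in a physicochemical assay for lipophilicity, read by HPLC, at pH 7.4; on this read-out higher numbers stand for higher lipophilicity and lower numbers for lower lipophilicity. In this assay compound 3 gives 4. Its nearest neighbour is compound 1 `Cc1csc(NC(=O)c2cc(C(C)(C)C)nn2Cc2ccccc2)n1`, which in this assay gives 4.7; furthest away is compound 2 `NCc1csc(NC(=O)c2cnnn2Cc2ccccc2)n1`, which in this assay gives 1.6. Compound 4 `CC(C)(C)c1cc(C(=O)Nc2ccccc2)n(Cc2ccccc2)n1` has not yet been measured. It differs from compound 3 in one place: phenyl in place of pyridin-4-yl on an amide-type nitrogen. Going by the values given here, the only measured step between compounds that differ in one place is a number 0.70 log units lower from compound 1 to compound 3 (beyond the scatter); it concerns a different replacement at the same amide-type nitrogen, so it gives no direct size for the present change, showing only that a swap at this position can move this assay beyond the scatter. Compound 2 has no single-point relation to compound 3, and its value marks only the low end of the set. The counted difference removes one hydrogen-bond acceptor and nothing else. The expected step is a number 1.20 log units higher from compound 3 to compound 4 (beyond the scatter), an increase. For compound 4 in this assay the estimate is 5.2, with a range from 4.6 to 5.8.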

Compound 4, distribution coefficient: 4.7
Compound 4: middle estimate off by 0.50 log units, on the high side; the range from low to high includes it.
By their numbers in this assay, from the lowest: compound 2; then compound 3; then compounds 1 and 4 (each within the scatter of the next).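

Phenyl in place of pyridin-4-yl on this amide-type nitrogen gives a number 0.70 log units higher from compound 3 to compound 4 (beyond the scatter) in this assay and so puts a direct size on a change that leaves the heavy-atom count the same and takes away one hydrogen-bond acceptor. Phenyl in place of 4-methyl-1,3-thiazol-2-yl gives no change at the digits printed from compound 1 to compound 4 (within the scatter) in the same assay, so among these three groups at this position, pyridin-4-yl alone stands apart, something the single earlier step could not show. Nothing measured here gives a reason for these steps.

Going by these compounds, all three groups at this position are aromatic rings, so it remains open how a cyclohexyl group, or a phenyl ring carrying a carboxylic acid or an amine, would read. On these data alone, it is also open whether the phenyl and pyridin-4-yl swap moves the number by a similar size on a different core.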